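Heteroaryl Exchange at the Acetyl Arm: Expectation for Compound 4

The compounds below may be only part of what the source reports. "The series", "measured", "known", "first", "only" and "open" are said of these compounds alone.

Measured in a functional assay for antagonist activity at P2X purinoceptor 7 (Rattus norvegicus), read by FLIPR and calcium flux; on this read-out lower numbers stand for stronger inhibition and higher numbers for weaker inhibition:
compound 1 `Cc1ccccc1N/C(=N\C#N)N1CCN(C(=O)Cc2ccoc2)C(c2ccccc2)C1` gives 250 nM
compound 2 `Cc1ccccc1N/C(=N\C#N)N1CCN(C(=O)Cc2ccsc2)C(c2ccccc2)C1` gives 270 nM
compound 3 `Cc1ccccc1N/C(=N\C#N)N1CCN(C(=O)Cc2cccnc2)C(c2ccccc2)C1` gives 390 nM

Compound 3 shows the highest number of the three, yet the steps of a 1.6-fold higher number from compound 1 to compound 3 (0.19 log units; within the scatter) and a 1.4-fold higher number from compound 2 to compound 3 (0.16 log units; within the scatter) both stay within the scatter, so no order among these compounds can be read from the numbers. Compound 4 `Cc1ccccc1N/C(=N\C#N)N1CCN(C(=O)Cn2nccc2C)C(c2ccccc2)C1` differs from compound 3 by 5-methyl-1H-pyrazol-1-yl in place of pyridin-3-yl on a saturated chain carbon bound to a carbonyl carbon. Among the compounds with values here, the steps that bear on this change are the earlier exchanges at the same carbon: a 1.1-fold higher number from compound 1 to compound 2 (0.03 log units; within the scatter), a 1.6-fold higher number from compound 1 to compound 3 (0.19 log units; within the scatter) and a 1.4-fold higher number from compound 2 to compound 3 (0.16 log units; within the scatter), none of which left the scatter. Replacing one small heteroaryl by another at this position has so far moved the read-out little, and the same is expected here: no step beyond the scatter, a 1.2-fold higher number from compound 3 to compound 4 (0.06 log units; within the scatter). Compound 4 is therefore estimated at 450 nM, with a range from 200 nM to 1000 nM.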

Compound 4, half-maximal inhibitory concentration: 560 nM
Compound 4: the middle estimate sits 1.2-fold (0.09 log units) below what was measured; low and high end bracket the measured number.
By their numbers in this assay, from the lowest: compounds 1, 2, 3 and 4 (each within the scatter of the next, the first and the last beyond it).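

In this assay, within the data shown here, the 5-methyl-1H-pyrazol-1-yl group is the only exchange at this carbon that leaves the scatter, with a 2.1-fold higher number from compound 2 to compound 4 (0.32 log units; beyond the scatter) and a 2.2-fold higher number from compound 1 to compound 4 (0.35 log units; beyond the scatter), both modest. Against pyridin-3-yl, however, it gives only a 1.4-fold higher number from compound 3 to compound 4 (0.16 log units; within the scatter), so the position responds modestly to some exchanges and compound 3 separates from neither end. Nothing available accounts for this shift. Still open, from the compounds shown here alone, is what this carbon would give with an unmethylated 1H-pyrazol-1-yl group, an amine or a longer chain.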